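The source may hold more compounds than are shown below. What is called first, only, known or untested is meant among the compounds shown, and "the series" means these compounds.

Working notes on the series. In a functional assay on PC-3 cells (Homo sapiens) for cytotoxicity, read by resazurin assay, with a stated time of 48 h (on this read-out lower numbers stand for stronger inhibition and higher numbers for weaker inhibition), compound 2 (`C=C(C)[C@@H]1CC=C(CN(OC)C2O[C@H](CNC(=O)CCCCCCCCC)[C@@H](O)[C@H](O)[C@H]2O)CC1`) gives 30000 nM, within the scatter of compound 1 (`C=C(C)[C@@H]1CC=C(CN(OC)C2O[C@H](CO)[C@@H](N=[N+]=[N-])[C@H](O)[C@H]2O)CC1`) at 22000 nM. Compound 3 (`C=CCOC(=O)N[C@H]1C(N(CC2=CC[C@@H](C(=C)C)CC2)OC)O[C@H](CO)[C@@H](O)[C@@H]1O`) reads 826000 nM, a much higher number and beyond the scatter of compound 2.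

Compound 4 (`C=CCOC(=O)NC[C@H]1OC(N(CC2=CC[C@@H](C(=C)C)CC2)OC)[C@H](O)[C@@H](O)[C@@H]1O`) departs from compound 2 at one place, with allyloxy in place of nonyl on a carbonyl carbon. Among the measured compounds shown here, compound 3, which also carries allyloxycarbonyl, reads 826000 nM, so a weaker result is expected for compound 4, though no measured pair isolates this change. The expected change, a 6.7-fold higher number from compound 2 to compound 4 (0.82 log units; beyond the scatter), is upward and beyond the scatter in this assay. Compound 4 is estimated at 200000 nM, within a range of 60000 nM to 700000 nM.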

Compound 4, half-maximal inhibitory concentration: 232000 nM
Estimate against measurement, compound 4: 1.2-fold (0.06 log units) below, within the range that was stated.
By their numbers in this assay, from the lowest: compounds 1 and 2 (each within the scatter of the next); then compound 4; then compound 3.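

In this assay, among the compounds shown here, allyloxy in place of nonyl on a carbonyl carbon gives a 7.7-fold higher number from compound 2 to compound 4 (0.89 log units; beyond the scatter), the first step that isolates a single place. The group on this carbonyl therefore matters in this assay, with nonyl giving the lower number. No measurement accompanying the step accounts for it.

This single step changes the chain and introduces the oxygen together, so their shares remain unseparated. As far as these compounds go, a longer chain on the same carbonyl, or a free amine in place of the amide-type nitrogen, remains open.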